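The source may hold more compounds than are shown below. What is called first, only, known or untested is meant among the compounds shown, and "the series" means these compounds.

Measured so far:
Compound 1 `CCn1cc(C(=O)N2N=C(c3cc4ccccc4o3)CC2c2ccccc2O)c(=O)c2ccc(C)nc21`. In an ADME assay on Vero cells (Chlorocebus sabaeus) for cytotoxicity, read by MTT assay, with a stated time of 72 h (a higher number here means a weaker inhibitor, a lower number a stronger inhibitor), compound 1 gives > 157000 nM, which is a limit of the assay and not a number.
Compound 2 `CCn1cc(C(=O)N2N=C(c3cc4ccccc4o3)CC2c2ccccc2C(=O)O)c(=O)c2ccc(C)nc21`. In this assay compound 2 gives > 196000 nM, again a limit of the assay rather than a number.

Going by the values given here, compound 2 therefore stands only at a limit, and the one further value shown, that of compound 1, is also a limit. Among the compounds with values here, the single measured step, a step that the two limits leave unreadable from compound 1 to compound 2, cannot be read in size because both ends sit at limits, the limit of > 157000 nM in this assay, at which 1 of the 2 values shown sits, and (the limit of > 196000 nM in this assay, at which 1 of the 2 values shown sits).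

Compound 3 `CCn1cc(C(=O)N2N=C(c3cc4ccccc4o3)CC2c2cccc([N+](=O)[O-])c2)c(=O)c2ccc(C)nc21` differs from compound 2 in one place: 3-nitrophenyl in place of 2-carboxyphenyl on a saturated ring carbon. Within the data shown here, no measured step bears on a nitro group, and the only step that is measured is unreadable, so the expected size of the step that the limit leaves unreadable from compound 2 to compound 3 in this assay is taken as none beyond the scatter, with compound 3 expected to remain at a limit. Compound 3 is estimated at 200000 nM, between 100000 nM and 400000 nM.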

Compound 3, half-maximal inhibitory concentration: > 164000 nM
Compound 3 ended at the assay's limit; the forecaster's own chance of this, stated with the estimate: 85%; the middle value does not contradict the limit.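

Going by these compounds alone, compound 1, compound 2 and compound 3 all sit at limits of this assay, so no step among them can be read in size. The compounds shown leave open where each true value lies, and whether 2-hydroxyphenyl, 2-carboxyphenyl and 3-nitrophenyl differ at all here.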